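A few compounds are considered here, and "the series" means these few. Any claim that something is new, unique, unknown or untested is made for them only; others in the source may bear on it.

Within the data shown here, the three compounds measured so far share one core and differ only in the group carried on the chain carbon bound to an aromatic nitrogen. Compound 1 `O=C(NCc1cn(Cc2ccc(C(F)(F)F)cc2)nn1)c1cn(-c2ccccc2)nc1-c1ccc(F)cc1` gives 760 nM in a functional assay on MIA PaCa-2 cells (Homo sapiens) for antiproliferative activity, read by sulforhodamine B assay, with a stated time of 48 h; a lower number here means a stronger inhibitor of growth, a higher number a weaker inhibitor of growth. Compound 2 `COc1ccc(Cn2cc(CNC(=O)c3cn(-c4ccccc4)nc3-c3ccc(F)cc3)nn2)cc1` gives 3700 nM in this assay, and that step is a 4.9-fold higher number from compound 1 to compound 2 (0.69 log units; beyond the scatter). Compound 3 `COc1ccc(Cn2cc(CNC(=O)c3cn(-c4ccccc4)nc3-c3ccc(F)cc3)nn2)cc1OC` reaches only the limit of this assay, > 100000 nM, so no number is known for it. The steps of an at least 27-fold higher number from compound 2 to compound 3 (1.43 log units; beyond the scatter) and an at least 130-fold higher number from compound 1 to compound 3 (2.11 log units; beyond the scatter) are both large, and the end point sits at the limit of > 100000 nM in this assay, at which 1 of the 3 values shown sits.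

Compound 4 `COc1ccc(-c2nn(-c3ccccc3)cc2C(=O)NCc2cn(Cc3ccc(OC)c(OC)c3)nn2)cc1` keeps everything of compound 3 and differs at the other aromatic ring: methoxy in place of fluoro on an aromatic carbon. Among the measured compounds shown here, no measured step exchanges fluoro for methoxy, so none bears on it directly; the steps that add or exchange a methoxy, a 4.9-fold higher number from compound 1 to compound 2 (0.69 log units; beyond the scatter) and an at least 27-fold higher number from compound 2 to compound 3 (1.43 log units; beyond the scatter), both raised the number. Compound 3 already stands at the limit. Compound 4 is therefore expected to remain at or beyond it, an expected step that the limit leaves unreadable from compound 3 to compound 4 to an estimated 150000 nM, in the range 40000 nM to 500000 nM.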

Compound 4, concentration for 50% growth inhibition: 16300 nM
The estimate for compound 4 lay 9.2-fold (0.96 log units) above the measured number, outside the stated range (below it).
By their numbers in this assay, from the lowest: compound 1; then compound 2; then compound 4. At a limit, above all of these: compound 3.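

In this assay the change from 4-fluorophenyl to 4-methoxyphenyl gives an at least 6.1-fold lower number from compound 3 to compound 4 (0.78 log units; beyond the scatter) and turns a limit into a measured number. Among these compounds, this shows that the aromatic ring carrying the fluoro group, left unchanged among the earlier compounds, also affects growth inhibition, and that a methoxy does not always weaken it: the earlier steps of a 4.9-fold higher number from compound 1 to compound 2 (0.69 log units; beyond the scatter) and an at least 27-fold higher number from compound 2 to compound 3 (1.43 log units; beyond the scatter) both went the other way. The full size of the new step cannot be read, because compound 3 has only a limit: the limit of > 100000 nM in this assay, at which 1 of the 4 values shown sits.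

The compounds shown leave open whether the same exchange would also lower the number when the 4-(trifluoromethyl)phenyl group of compound 1 is present. They also leave open how an amine, a hydroxyl or a longer ethoxy chain would compare at this position.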